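Swapping Chloro for Methoxy on the Pendant Phenyl

This account rests on a few compounds, and the source may have more. Where it says the series, first, only, none or still open, it means among the compounds named here.

Of the compounds shown here, three sharing one core have been tested in a functional assay on SMMC-7721 cells (Homo sapiens) for cytotoxicity, read by MTT assay, with a stated time of 4 days; a lower number here means a stronger inhibitor, a higher number a weaker inhibitor. Compound 1 `C=C1C[C@]23C[C@@]1(O)CC[C@@H]2c1cccc(C)c1[C@@H]3Cn1cc(-c2ccccc2)nn1` gives only a limit, > 20000 nM. Compound 2 `C=C1C(=O)[C@]23C[C@@]1(O)CC[C@H]2c1ccc(O)c(C)c1[C@@H]3Cn1cc(-c2ccc(Br)cc2)nn1` gives 1300 nM, and compound 3 `C=C1C(=O)[C@]23C[C@@]1(O)CC[C@H]2c1ccc(O)c(C)c1[C@@H]3Cn1cc(-c2ccc(Cl)cc2)nn1` gives 670 nM; these two numbers lie within the scatter of each other, as the step of a 1.9-fold lower number from compound 2 to compound 3 (0.29 log units; within the scatter) shows, so neither can be called the stronger. Compound 4 `C=C1C(=O)[C@]23C[C@@]1(O)CC[C@H]2c1ccc(O)c(C)c1[C@@H]3Cn1cc(-c2ccc(OC)cc2)nn1` is compound 3 with methoxy in place of chloro on an aromatic carbon. Only the bromo-to-chloro step bears on this change, and it stayed within the scatter. With no measured guide to a methoxy at this place, a small step, or none beyond the scatter, is expected in this assay. Compound 4 is therefore expected near 1000 nM, between 400 nM and 3000 nM, an estimated step of a 1.5-fold higher number from compound 3 to compound 4 (0.17 log units; within the scatter).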

Compound 4, half-maximal inhibitory concentration: 860 nM
Estimate against measurement, compound 4: 1.2-fold (0.07 log units) above; the measured number falls inside the stated range.
By their numbers in this assay, from the lowest: compounds 3, 4 and 2 (each within the scatter of the next). At a limit, above all of these: compound 1.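

In this assay, the earlier pair held only two halogens, bromo and chloro. Methoxy brings oxygen and a hydrogen-bond acceptor to the same carbon, yet the values stay within the scatter of each other, with a 1.3-fold higher number from compound 3 to compound 4 (0.11 log units; within the scatter) and a 1.5-fold lower number from compound 2 to compound 4 (0.18 log units; within the scatter). On this evidence, the three groups at this place cannot be told apart, and nothing measured here accounts for their closeness. On these data alone, whether an amine, a carboxylic acid or a longer chain at this place would give a value beyond the scatter remains open.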